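The source may hold more compounds than are shown below. What is called first, only, known or untested is meant among the compounds shown, and "the series" means these compounds.

Measured compounds, with the read-out from an ADME assay on MT4 cells (Homo sapiens) for cytotoxicity, read by MTT assay, with a stated time of 5 days; on this read-out higher numbers stand for lower toxicity in this test and lower numbers for higher toxicity in this test:
- compound 1, `N#Cc1ccccc1CN1C(=O)N(Cc2cccc(F)c2)S(=O)(=O)n2cccc21`: > 305000 nM, a limit of the test rather than a number
- compound 2, `O=C1N(Cc2ccccc2Cl)c2cccn2S(=O)(=O)N1Cc1cccc(F)c1`: 231000 nM
- compound 3, `O=C1N(Cc2ccccc2Cl)c2cccn2S(=O)(=O)N1Cc1ccccc1`: > 291000 nM, a limit of the test rather than a number

Among the compounds with values here, compound 2 is the only member with a numerical value in this assay. Compound 1 differs from it by cyano in place of chloro on an aromatic carbon, and the step is an at least 1.3-fold higher number from compound 2 to compound 1 (0.12 log units; that floor lies within the scatter). The cores of compound 2 and compound 3 differ by hydrogen in place of fluoro on an aromatic carbon, and that step is an at least 1.2-fold higher number from compound 2 to compound 3 (0.10 log units; that floor lies within the scatter). Neither step can be sized beyond its floor because compound 1 sits at the limit of > 305000 nM in this assay, at which 1 of the 3 values shown sits, and compound 3 sits at the limit of > 291000 nM in this assay, at which 1 of the 3 values shown sits.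

Compound 4, `N#Cc1ccccc1CN1C(=O)N(Cc2ccccc2)S(=O)(=O)n2cccc21`, differs from compound 3 by cyano in place of chloro on an aromatic carbon. The place matches word for word that of the change from compound 2 to compound 1, so it is the same change. The step from compound 3 to compound 4 is expected to be a step that the limit leaves unreadable from compound 3 to compound 4, resting on an at least 1.3-fold higher number from compound 2 to compound 1 (0.12 log units; that floor lies within the scatter) and on compound 3 already standing at the limit of > 291000 nM in this assay, at which 1 of the 3 values shown sits. Compound 4 is therefore estimated at 320000 nM in this assay, most likely returned as a limit again.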

Compound 4, half-maximal cytotoxic concentration: > 318000 nM
Compound 4 ended at the assay's limit; the forecaster's own chance of this, stated with the estimate: 75%; the middle value lies beyond the limit too.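

In this assay, compound 4 stands at a limit of the test, as do compound 1 and compound 3, so neither its step from compound 3 nor its step from compound 1 can be read. The compounds shown leave open where the true values of compound 1, compound 3 and compound 4 lie, and whether they differ at all.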